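The source may report more compounds than this note shows. Statements on the series, on what has been measured and on what is new or still open speak of the compounds shown alone.

For the measured compounds named here, the two compounds measured so far share one core and differ only in the placement of a substituent on it. Compound 1 `ClCc1ccccc1Cn1cnc2c(Cl)nc(Cl)nc21` and compound 2 `ClCc1ccc(Cn2cnc3c(Cl)nc(Cl)nc32)cc1` were both tested in a functional assay on MCF7 cells (Homo sapiens) for cytotoxicity, read by sulforhodamine B assay, with a stated time of 48 h; on this read-out higher numbers stand for weaker inhibition of growth and lower numbers for stronger inhibition of growth: compound 1 gives 810 nM, and compound 2 gives 1740 nM. Compound 1 therefore has the lowest number of the two, and its gap to compound 2 lies beyond the usual scatter of repeated measurements, so the two results can be told apart.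

Compound 3 `Nc1nc(Cl)c2ncn(Cc3ccccc3CCl)c2n1` is the next question. It differs from compound 1 in a single place: amino in place of chloro on an aromatic carbon, on the aromatic carbon between two ring nitrogen atoms, meta to a chloro group. Going by the values given here, no measured pair here shows what this swap does, so any expectation for compound 3 rests on compound 1 alone, whose value is 810 nM. The expected step in this assay is a 1.7-fold higher number from compound 1 to compound 3 (0.24 log units; within the scatter), a small one, leaning toward a weaker result, and it might well stay within the scatter. For compound 3 the estimate is 1400 nM, with a range from 450 nM to 4500 nM.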

Compound 3, concentration for 50% growth inhibition: 6030 nM
Estimate against measurement, compound 3: 4.3-fold (0.63 log units) below; the measured number lies above the stated range.
By their numbers in this assay, from the lowest: compound 1; then compound 2; then compound 3.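

In this assay, placing amino instead of chloro on the aromatic carbon between two ring nitrogen atoms gives a 7.4-fold higher number from compound 1 to compound 3 (0.87 log units; beyond the scatter), so growth inhibition weakens clearly with this swap. For the compounds shown here, compound 1 and compound 2 differ only in where a substituent sits, so they said nothing about this carbon; compound 3 is the first sign that the group here matters, at least on the core of compound 1. Nothing available explains the weaker result, and one pair cannot separate the loss of chloro from the arrival of amino, or from the hydrogen-bond donor and acceptor counted with it.

On these data alone, what remains open is how other groups would behave on this same carbon, for example a methylamino, a methoxy, a hydroxyl or a plain methyl group, and whether any of them could match chloro here. As far as these compounds go, it is also open whether the same swap would weaken compound 2 in this assay to a similar extent, and what a change at the other chloro group on the core would do.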